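The source may hold more compounds than are shown below. What is called first, only, known or untested is meant among the compounds shown, and "the series" means these compounds.

Compound 2 `Cn1c(I)nc2ccccc21` is the strongest of the two compounds with a numerical result in a functional assay on NCI-H522 cells (Homo sapiens) for cytotoxicity, with a stated time of 3 days; a lower number here means a stronger inhibitor, a higher number a weaker inhibitor: compound 2 gives 1020 nM. Compound 1 `C#Cc1nc2ccccc2n1C` gives 8140 nM, and the step of an 8.0-fold lower number from compound 1 to compound 2 (0.90 log units; beyond the scatter) came from putting iodo in place of ethynyl on an aromatic carbon. Compound 3 `C=Cc1nc(C(=O)OCC)cs1`, built on a different core, reached only (the limit of > 40000 nM in this assay, at which 1 of the 3 values shown sits), so its value > 40000 nM is a limit rather than a number.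

Compound 4 `Cn1cnc2ccccc21` differs from compound 2 by hydrogen in place of iodo on an aromatic carbon. Among the measured compounds shown here, the only measured step that touches the same position, an 8.0-fold lower number from compound 1 to compound 2 (0.90 log units; beyond the scatter), shows that the iodo atom is worth a modest gain over ethynyl; taking it away altogether and leaving a bare hydrogen is therefore expected to cost potency, most likely by a similar or somewhat larger amount, with the direction toward a higher number in this assay. The expected step is a 7.8-fold higher number from compound 2 to compound 4 (0.89 log units; beyond the scatter). Compound 4 is estimated to give 8000 nM, within the range 2500 nM to 30000 nM.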

Compound 4, half-maximal inhibitory concentration: > 40000 nM
Compound 4 was reported as a limit; the forecaster's own chance of this, stated with the estimate: 15%; middle value at least 5.0-fold (0.69 log units) away from the limit.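

Replacing a group on the aromatic carbon between the two ring nitrogen atoms with hydrogen gives an at least 39-fold higher number from compound 2 to compound 4 (1.59 log units; beyond the scatter) in this assay, and the same replacement of ethynyl gives an at least 4.9-fold higher number from compound 1 to compound 4 (0.69 log units; beyond the scatter). The earlier comparison ranked iodo against ethynyl only, whereas these steps set both groups against a bare hydrogen and show that each carries activity that hydrogen does not, with iodo ahead of ethynyl. Compound 4 stands at a limit and not at a number, so both steps give only a minimum size: the limit of > 40000 nM in this assay, at which 2 of the 4 values shown sit.

The compounds shown leave open whether this gain is particular to iodo or is shared by other groups on this carbon, such as chloro, bromo, an amine or a longer chain. On these data alone, the true size of both steps also remains open.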